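Benzimidazole-type nucleosides: a trifluoromethylphenyl replacement for ethynyl

This account rests on a few compounds, and the source may have more. Where it says the series, first, only, none or still open, it means among the compounds named here.

Compound 1 `C#CCSc1nc2cc(Cl)c(Cl)cc2n1C1O[C@H](CO)[C@@H](O)[C@H]1O`: 60000 nM
Compound 2 `Cc1cccc(CSc2nc3cc(Cl)c(Cl)cc3n2C2O[C@H](CO)[C@@H](O)[C@H]2O)c1`: 30000 nM

In a functional assay on KB cells (Homo sapiens) for inhibition (on this read-out higher numbers stand for weaker inhibition and lower numbers for stronger inhibition), compound 1 gives 60000 nM, the highest of the two numbers recorded; its nearest neighbour is compound 2, which gives 30000 nM. For the measured compounds named here, the only measured step that bears on the present question runs a 2.0-fold lower number from compound 1 to compound 2 (0.30 log units; within the scatter). Compound 3 `OC[C@H]1OC(n2c(SCc3cccc(C(F)(F)F)c3)nc3cc(Cl)c(Cl)cc32)[C@H](O)[C@@H]1O` has not yet been measured in this assay. Its difference from compound 1 is 3-(trifluoromethyl)phenyl in place of ethynyl on a saturated chain carbon bound to a sulfur. Since the measured aryl-for-ethynyl change from compound 1 to compound 2 stayed within the scatter, the step from compound 1 to compound 3 is expected to be of a similar size, that is a 2.0-fold lower number from compound 1 to compound 3 (0.30 log units; within the scatter), and not clearly beyond the scatter in either direction. Compound 3 is therefore estimated at 30000 nM, with a range from 10000 nM to 100000 nM in this assay.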

Compound 3, half-maximal inhibitory concentration: 15000 nM
Estimate against measurement, compound 3: 2.0-fold (0.30 log units) above; low and high end bracket the measured number.
By their numbers in this assay, from the lowest: compounds 3, 2 and 1 (each within the scatter of the next, the first and the last beyond it).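

In this assay, 3-(trifluoromethyl)phenyl in place of ethynyl on a saturated chain carbon bound to a sulfur gives a 4.0-fold lower number from compound 1 to compound 3 (0.60 log units; beyond the scatter) and so takes this position beyond the scatter, which the 3-methylphenyl group of compound 2 did not do. Trifluoromethyl in place of methyl on an aromatic carbon gives only a 2.0-fold lower number from compound 2 to compound 3 (0.30 log units; within the scatter) and so leaves compound 2 and compound 3 unresolved, which means that the gain over compound 1 cannot be assigned to the trifluoromethyl group itself. No measurement offered here accounts for either step.

On these data alone, it remains open whether an unsubstituted phenyl group on this chain carbon would read like compound 2 and compound 3. Also open, as far as these compounds go, is how a carboxylic acid or an amine on the aromatic ring, or a longer chain in its place, would read in this assay.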